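The compounds below may be only part of what the source reports. "The series", "measured", "known", "first", "only" and "open" are said of these compounds alone.

Compound 1 `COc1cc(-c2nn(-c3cccc(NC(=O)Nc4cc(C(F)(F)F)cc(C(F)(F)F)c4)c3)cc2-c2ccncc2)ccc1Cl` is the reference point of this account. In a functional assay on Malme-3M cells (Homo sapiens) for inhibition, read by sulforhodamine B assay, with a stated time of 48 h (on this read-out higher numbers stand for weaker inhibition of growth and lower numbers for stronger inhibition of growth), compound 1 gives 892 nM. Two other compounds have been run in the same test. Compound 2 `COc1cc(-c2nn(-c3cccc(NC(=O)c4cccc(C(F)(F)F)c4)c3)cc2-c2ccncc2)ccc1Cl` gives 1990 nM in this assay, and compound 3 `O=C(Nc1cccc(-n2cc(-c3ccncc3)c(-c3ccc(Cl)c(O)c3)n2)c1)Nc1ccc(Cl)c(Cl)c1` gives 1190 nM in this assay. Among these three numbers compound 1 has the smallest; compound 3 sits within the scatter of it, so the two cannot be ordered, while compound 2 lies beyond the scatter and so is the weaker grower-inhibitor of the pair. No two of these measured compounds differ in a single place, so no isolated step can be read from them.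

Compound 4 `COc1cc(-c2nn(-c3cccc(NC(=O)Nc4cccc(C(F)(F)F)c4)c3)cc2-c2ccncc2)ccc1Cl` has not yet been measured. It is obtained from compound 1 by one change: hydrogen in place of trifluoromethyl on an aromatic carbon. Nothing in the measured set isolates this change; compound 2 also carries a single trifluoromethyl but differs from compound 1 in more than one place. On that basis a modest rise in the number, of a size near the edge of the scatter, is expected for compound 4 in this assay, so that the estimated step of a 1.6-fold higher number from compound 1 to compound 4 (0.20 log units; within the scatter) points toward weaker inhibition. Compound 4 is therefore estimated at 1400 nM, with a range from 500 nM to 4000 nM.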

Compound 4, concentration for 50% growth inhibition: 1050 nM
Beside the measured number, compound 4's estimate is 1.3-fold (0.12 log units) above it; the measured number falls inside the stated range.
By their numbers in this assay, from the lowest: compounds 1, 4, 3 and 2 (each within the scatter of the next, the first and the last beyond it).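

Hydrogen in place of trifluoromethyl on an aromatic carbon, meta to a trifluoromethyl group, gives in this assay a step (a 1.2-fold higher number from compound 1 to compound 4 (0.07 log units; within the scatter)) that lies within the scatter, so this position is the first one isolated here, and the loss of these 4 heavy atoms produces no change that can be read. Within the data shown here, the first single-place comparison at the carbonyl carbon, (3-(trifluoromethyl)phenyl)amino in place of 3-(trifluoromethyl)phenyl, gives a step (a 1.9-fold lower number from compound 2 to compound 4 (0.28 log units; within the scatter)) that also stays within the scatter, so that change cannot be told apart from repeat variation either. Nothing is available that bears on why these two steps are as small as they are.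

As far as these compounds go, whether any other substituent on that aromatic carbon, such as an amine, a methoxy group or a carboxylic acid, would move the number beyond the scatter remains open. The compounds shown also leave open what happens when the remaining trifluoromethyl of compound 4 gives way to hydrogen or to a nitrile, and so whether the ring needs any substituent at all.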